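A Methyl-to-Chloro Swap at the Edge of Compound 1

This account rests on a few compounds, and the source may have more. Where it says the series, first, only, none or still open, it means among the compounds named here.

Compound 1 `Cc1ccc([C@@H](C)Oc2cc3onc(CCC(=O)O)c3cc2Cl)nc1`: 1.59 nM
Compound 2 `O=C(O)CCn1c(=O)oc2cc(OCc3ccccc3)c(Cl)cc21`: 1580 nM

Both numbers come from an assay on HEK293 cells for inhibition of kynurenine 3-monooxygenase (Homo sapiens), read by LC-MS, with a stated time of 20 h; on this read-out higher numbers stand for weaker inhibition and lower numbers for stronger inhibition. Compound 1 has the lower of the two numbers, and compound 2 sits far higher, a gap well beyond the usual scatter. Compound 3 `C[C@@H](Oc1cc2onc(CCC(=O)O)c2cc1Cl)c1ccc(Cl)cn1` has not yet been measured. It differs from compound 1 in one place: chloro in place of methyl on an aromatic carbon. Going by the values given here, no measured pair shows what such a swap does here, so the expectation is for a change that stays within the scatter of this assay. For compound 3 the estimated value is 2 nM, with a range from 0.6 nM to 6.5 nM. This estimate means an expected step of a 1.3-fold higher number from compound 1 to compound 3 (0.10 log units; within the scatter).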

Compound 3, half-maximal inhibitory concentration: 3.98 nM
Compound 3: middle estimate off by 2.0-fold (0.30 log units), on the low side; measured number inside the range.
By their numbers in this assay, from the lowest: compound 1; then compound 3; then compound 2.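

In this assay the change from 5-methylpyridin-2-yl to 5-chloropyridin-2-yl gives a 2.5-fold higher number from compound 1 to compound 3 (0.40 log units; beyond the scatter) as its step. This position therefore accepts chloro with only a modest cost, yet methyl and chloro are not interchangeable here. Nothing measured among these compounds explains the step.

From the compounds shown here alone, whether fluoro, methoxy or a nitrile at this place would match methyl or chloro remains open. Also open, going by these compounds, is whether an amine there would hold the number as low, or whether the same swap would cost as much on a different core.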